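Changing the Acyl Side Chain of Compound 3

The source may hold more compounds than are shown below. What is called first, only, known or untested is meant among the compounds shown, and "the series" means these compounds.

Compound 1 (`CN(C)C12CC(c3ccccc3)C(CN(C(=O)CN3CCCC3)C1)C(c1ccccc1)C2`) at 12600 nM
Compound 2 (`CN1CCN(CC(=O)N2CC3C(c4ccccc4)CC(N(C)C)(CC3c3ccccc3)C2)CC1`) at 9250 nM
Compound 3 (`CCN(CC)CCC(=O)N1CC2C(c3ccccc3)CC(N(C)C)(CC2c2ccccc2)C1`) at 15400 nM

In an ADME assay on L6 cells (Rattus norvegicus) for cytotoxicity, read by resazurin assay, with a stated time of 72 h (a lower number here means a stronger inhibitor, a higher number a weaker inhibitor), compound 3 cannot be separated from the other two. The steps leading to it are a 1.2-fold higher number from compound 1 to compound 3 (0.09 log units; within the scatter) and a 1.7-fold higher number from compound 2 to compound 3 (0.22 log units; within the scatter) while the remaining step is a 1.4-fold lower number from compound 1 to compound 2 (0.13 log units; within the scatter) in this set.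

Compound 4 (`CN(C)C12CC(c3ccccc3)C(CN(CCN3CCCCC3)C1)C(c1ccccc1)C2`) differs from compound 3 as follows: 2-(piperidin-1-yl)ethyl in place of (2-(diethylamino)ethyl)carbonyl on an amine nitrogen in a ring in words, 2-(piperidin-1-yl)ethyl in place of (2-(diethylamino)ethyl)carbonyl on an amine nitrogen in a ring. The three measured steps only exchange the group on a saturated chain carbon bound to a carbonyl carbon. For the measured compounds named here, compound 3 at 15400 nM is the starting point, and no measured compound lacks the carbonyl, so those steps set no firm size here. A modest step to a lower number is expected in this assay as the estimate a 2.2-fold lower number from compound 3 to compound 4 (0.34 log units; beyond the scatter) with wide margins. For compound 4 the expected value is 7000 nM within an estimated range of 2500 nM to 18000 nM overall.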

Compound 4, half-maximal inhibitory concentration: 2920 nM
The estimate for compound 4 lay 2.4-fold (0.38 log units) above the measured number; the measured number falls inside the stated range.
By their numbers in this assay, from the lowest: compound 4; then compounds 2, 1 and 3 (each within the scatter of the next).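

In this assay, for the compounds shown here, 2-(piperidin-1-yl)ethyl on the amine nitrogen in the ring gives the first steps in this set that lie beyond the scatter (a 5.3-fold lower number from compound 3 to compound 4 (0.72 log units; beyond the scatter)) (a 3.2-fold lower number from compound 2 to compound 4 (0.50 log units; beyond the scatter)) (a 4.3-fold lower number from compound 1 to compound 4 (0.63 log units; beyond the scatter)). Exchanging the group on the saturated chain carbon bound to the carbonyl carbon had left compounds 1, 2 and 3 within the scatter of one another, whereas compound 4, which has no carbonyl in this substituent, stands apart from all three, so this position does respond to a change of the whole substituent. Nothing available explains this difference.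

The carbonyl leaves and the piperidine ring enters in the same change, so the compounds shown do not separate the two. Going by these compounds, a 2-(diethylamino)ethyl or 2-(pyrrolidin-1-yl)ethyl group on the same nitrogen would address this, and the effect of a longer chain also remains open.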